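This account rests on a few compounds, and the source may have more. Where it says the series, first, only, none or still open, it means among the compounds named here.

Of the compounds shown here, three sharing one core have been tested in a functional assay on HeLa cells (Homo sapiens) for antiproliferative activity, read by sulforhodamine B assay, with a stated time of 72 h; on this read-out lower numbers stand for stronger inhibition and higher numbers for weaker inhibition. Compound 1 `Cc1cc(NS(=O)(=O)c2ccc(Nc3nncc4ccccc34)cc2)no1` gives 13 nM. Compound 2 `Cc1cc(C)nc(NS(=O)(=O)c2ccc(Nc3nncc4ccccc34)cc2)n1` gives 3.5 nM. Compound 3 `NS(=O)(=O)c1ccc(Nc2nncc3ccccc23)cc1` gives 12 nM, the second highest of the three numbers, close to compound 1 and further from compound 2. Compound 4 `O=S(=O)(Nc1ncccn1)c1ccc(Nc2nncc3ccccc23)cc1` has not yet been measured; it differs from compound 3 by pyrimidin-2-yl in place of hydrogen on a sulfonamide nitrogen.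

Within the data shown here, two measured steps bear on this change. The step of a 3.4-fold higher number from compound 2 to compound 3 (0.54 log units; beyond the scatter) shows that taking a 4,6-dimethylpyrimidin-2-yl group off the sulfonamide nitrogen raises the number modestly, so putting a related ring back on could lower it. Yet the step of a 1.1-fold lower number from compound 1 to compound 3 (0.03 log units; within the scatter) shows that taking off a 5-methyl-1,2-oxazol-3-yl group changes nothing beyond the scatter, so not every group at that place matters. The pyrimidin-2-yl group entering compound 4 resembles the group of compound 2 without its methyl groups. A modest lowering, a 2.4-fold lower number from compound 3 to compound 4 (0.38 log units; beyond the scatter), is therefore expected. Compound 4 is estimated at 5 nM, between 2 nM and 14 nM.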

Compound 4, half-maximal inhibitory concentration: 14 nM
Compound 4: the middle estimate sits 2.8-fold (0.45 log units) below what was measured; measured number inside the range.
By their numbers in this assay, from the lowest: compound 2; then compounds 3, 1 and 4 (each within the scatter of the next).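

In this assay, putting a plain pyrimidin-2-yl ring on the sulfonamide nitrogen changes nothing beyond the scatter (a 1.2-fold higher number from compound 3 to compound 4 (0.07 log units; within the scatter)), and the same holds when it replaces the 5-methyl-1,2-oxazol-3-yl group (a 1.1-fold higher number from compound 1 to compound 4 (0.03 log units; within the scatter)). The ring alone therefore does not account for the lower number of compound 2: without the two methyl groups of the 4,6-dimethylpyrimidin-2-yl group, the number rises modestly (a 4.0-fold higher number from compound 2 to compound 4 (0.60 log units; beyond the scatter)), so among these four compounds, only compound 2 stands apart beyond the scatter. Nothing measured here explains this difference.

On these data alone, it remains open whether a single methyl group on the pyrimidin-2-yl ring would give the same lowering as two. As far as these compounds go, it is also open whether ethyl or methoxy groups in those places would do so.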